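From Compound 2 to Compound 3 on the Sulfur Chain

The source may report more compounds than this note shows. Statements on the series, on what has been measured and on what is new or still open speak of the compounds shown alone.

In a functional assay on HepG2 cells (Homo sapiens) for inhibition, read by MTT assay, with a stated time of 48 h (on this read-out higher numbers stand for weaker inhibition and lower numbers for stronger inhibition), compound 1 `COc1ccc(-n2c(SC)nnc2-c2cc(OC)c(OC)c(OC)c2)cc1` gives > 60000 nM as its reading, which is a limit and not a number. Within the data shown here, compound 2 `COc1ccc(-n2c(SCc3ccc(F)cc3)nnc2-c2cc(OC)c(OC)c(OC)c2)cc1` reads 35000 nM and holds the only exact number so far, so it cannot yet be ranked against a second number. Among the measured compounds shown here, one measured step bears on what follows. Placing 4-fluorophenyl in place of hydrogen on a saturated chain carbon bound to a sulfur gave an at least 1.7-fold lower number from compound 1 to compound 2 (0.23 log units; that floor lies within the scatter) as its size, a floor that stays within the scatter. Compound 3 `COc1ccc(-n2c(SCC(=O)c3ccc4ccccc4c3)nnc2-c2cc(OC)c(OC)c(OC)c2)cc1` has not been measured. It differs from compound 2 by the change (naphthalen-2-yl)carbonyl in place of 4-fluorophenyl on a saturated chain carbon bound to a sulfur at that same place, that is, (naphthalen-2-yl)carbonyl in place of 4-fluorophenyl on a saturated chain carbon bound to a sulfur. For the measured compounds named here, with compound 2 at 35000 nM as the starting point and the step of an at least 1.7-fold lower number from compound 1 to compound 2 (0.23 log units; that floor lies within the scatter) as the sole guide, a moderate move toward a lower number is expected in this assay for this swap. The expected size is a 2.3-fold lower number from compound 2 to compound 3 (0.37 log units; beyond the scatter) and no more than that. Compound 3 is estimated at 15000 nM with 4000 nM to 50000 nM as the expected range.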

Compound 3, half-maximal inhibitory concentration: > 60000 nM
Compound 3: a limit, no number; the forecaster's own chance of this, stated with the estimate: 15%; middle value at least 4.0-fold (0.60 log units) away from the limit.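

On the saturated chain carbon bound to a sulfur, (naphthalen-2-yl)carbonyl in place of 4-fluorophenyl yielded no exact number: in this assay compound 3 gives > 60000 nM, which is a limit of the assay and not a number. The change comes to an at least 1.7-fold higher number from compound 2 to compound 3 (0.23 log units; that floor lies within the scatter), so the larger group, with its carbonyl and 2 six-membered aromatic rings, did not carry the reading to a lower number than that of compound 2, although the floor of this step does not clear the usual scatter. The true size of this change stays unknown, and the step joining compound 1 and compound 3 cannot be read, because both readings are limits: the limit of > 60000 nM in this assay, at which 2 of the 3 values shown sit.

Compound 3 brings in the carbonyl and the second aromatic ring together, so the compounds shown leave open which of the two parts matters for the reading. A phenylcarbonyl group on the same chain carbon would separate those two parts, while an amine or a carboxylic acid there would show whether anything other than an aromatic group can give an exact number at this position.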